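The compounds below may be only part of what the source reports. "The series", "measured", "known", "first", "only" and "open" are said of these compounds alone.

Measured compounds in an assay on HEK293 cells for agonist activity at Toll-like receptor 2 (Homo sapiens); on this read-out lower numbers stand for an effect already at smaller amounts and higher numbers for an effect only at larger amounts of compound:
- compound 1, `CCCCCCCCCCCC(=O)OC[C@H](CSC[C@@H](N)C(=O)NCCCCCCO)OC(=O)CCCCCCCCCCC`: 33 nM
- compound 2, `CCCCCCCCCCCC(=O)OC[C@H](CSC[C@@H](N)C(=O)NCCCS(=O)(=O)O)OC(=O)CCCCCCCCCCC`: 5560 nM
- compound 3, `CCCCCCCCCCCC(=O)OC[C@H](CSC[C@@H](N)C(=O)NCCOCCOS(=O)(=O)O)OC(=O)CCCCCCCCCCC`: 61 nM

All three share the same lipid-bearing core and differ only in the chain attached to the amide nitrogen. Compound 3 stands second highest of these three numbers; its nearest neighbour is compound 1, at a distance that is within the scatter of this assay, while compound 2 lies far away from it, as the step of a 91-fold lower number from compound 2 to compound 3 (1.96 log units; beyond the scatter) shows.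

Compound 4, `CCCCCCCCCCCC(=O)OC[C@H](CSC[C@@H](N)C(=O)NCCOCCOCCOCCC(=O)O)OC(=O)CCCCCCCCCCC`, has not yet been measured in this assay. It differs from compound 3 in one place: 2-(2-carboxyethoxy)ethyl in place of sulfo on an oxygen on a saturated carbon. Two of the measured steps bear on this change. The step of a 1.8-fold higher number from compound 1 to compound 3 (0.27 log units; within the scatter) shows that exchanging a hydroxy-terminated chain for a sulfooxy-terminated ether chain left the number essentially unchanged. The step of a 170-fold higher number from compound 1 to compound 2 (2.23 log units; beyond the scatter) shows that a sulfo group set close to the amide nitrogen on a short chain raised the number strongly. Compound 4 keeps an acidic group at the far end of an extended ether chain, which resembles the arrangement in compound 3 more than that in compound 2. The expected step of a 1.5-fold higher number from compound 3 to compound 4 (0.17 log units; within the scatter) is therefore none beyond the scatter, or at most a modest rise. For compound 4 the estimate in this assay is 90 nM, with a range from 25 nM to 400 nM.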

Compound 4, half-maximal effective concentration: 900 nM
Estimate against measurement, compound 4: 10-fold (1.00 log units) below, and the stated range ends below it.
By their numbers in this assay, from the lowest: compounds 1 and 3 (each within the scatter of the next); then compound 4; then compound 2.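

In this assay, among these compounds, the oxygen at the end of the ether chain turns out to be far less forgiving than the earlier compounds suggested: putting 2-(2-carboxyethoxy)ethyl in place of sulfo gives a 15-fold higher number from compound 3 to compound 4 (1.17 log units; beyond the scatter) and shows that an ether chain ending in another group need not behave like the one in compound 3. Measured against the other two chains, this one falls in the middle, with a 27-fold higher number from compound 1 to compound 4 (1.44 log units; beyond the scatter) but also a 6.2-fold lower number from compound 2 to compound 4 (0.79 log units; beyond the scatter), so it sits well behind the hydroxy-terminated chain and still ahead of the short sulfo chain. Nothing available explains why this change has so large an effect on the number.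

Compound 4 differs from compound 3 in both its end group and its chain length, so these compounds cannot show which of the two matters; a sulfooxy group on the longer ether chain, or a carboxylic acid on the shorter one, would separate them. From the compounds shown here alone, how an amine or a phosphate at the end of the chain would compare also remains open.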